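Ester to alcohol on a tetrahydropyran side chain

The source may hold more compounds than are shown below. What is called first, only, known or untested is meant among the compounds shown, and "the series" means these compounds.

The measured compounds in a functional assay on MCF7S cells (Homo sapiens); a higher number here means a weaker inhibitor of growth, a lower number a stronger inhibitor of growth:
compound 1, `COC(=O)/C=C/C[C@H]1OCCC[C@@H]1O[Si](C)(C)C(C)(C)C`, gives 18000 nM;
compound 2, `CC(C)(C)[Si](C)(C)O[C@H]1CCCO[C@@H]1C/C=C/CO`, gives 25000 nM;
compound 3, `COC(=O)/C=C/[C@H]1OCCC[C@@H]1O[Si](C)(C)C(C)(C)C`, gives 24000 nM.

All three compounds share a silyl-protected tetrahydropyran core and differ in the unsaturated side chain. Going from compound 1 to compound 2 the change is hydroxymethyl in place of methoxycarbonyl on a double-bonded chain carbon bound to a double-bonded chain carbon, and this step in this assay is a 1.4-fold higher number from compound 1 to compound 2 (0.14 log units; within the scatter). Compound 3 carries the shorter chain; the difference between its core and that of compound 1 is 2-(methoxycarbonyl)ethenyl in place of 3-(methoxycarbonyl)prop-2-en-1-yl on a saturated ring carbon, and the step is a 1.3-fold higher number from compound 1 to compound 3 (0.12 log units; within the scatter). Compound 2 and compound 3 sit together as well: a 1.0-fold lower number from compound 2 to compound 3 (0.02 log units; within the scatter).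

Compound 4, `CC(C)(C)[Si](C)(C)O[C@H]1CCCO[C@@H]1/C=C/CO`, has not yet been measured. It differs from compound 3 by hydroxymethyl in place of methoxycarbonyl on a double-bonded chain carbon bound to a double-bonded chain carbon. The place of this change is worded exactly as it is for the change from compound 1 to compound 2, so the same change is made on the shorter chain of compound 3. Since compound 1 and compound 2 showed only a 1.4-fold higher number from compound 1 to compound 2 (0.14 log units; within the scatter), the step from compound 3 to compound 4 in this assay is expected to be of similar size, a 1.3-fold higher number from compound 3 to compound 4 (0.10 log units; within the scatter), which rests solely on that one earlier pair. The estimate for compound 4 is therefore 30000 nM, with a range expected from 14000 nM to 65000 nM.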

Compound 4, concentration for 50% growth inhibition: 61000 nM
Compound 4: middle estimate off by 2.0-fold (0.31 log units), on the low side; low and high end bracket the measured number.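

In this assay, hydroxymethyl in place of methoxycarbonyl on the shorter chain gives a 2.5-fold higher number from compound 3 to compound 4 (0.41 log units; beyond the scatter), a step beyond the scatter, while the same change on the longer chain stayed within it, yet the two steps cannot be told apart: the same change on two cores in this assay, a 1.4-fold higher number (0.14 log units; within the scatter) from compound 1 to compound 2 and a 2.5-fold higher number (0.41 log units; beyond the scatter) from compound 3 to compound 4, 1.8-fold (0.26 log units) apart, within the scatter of two such steps. The two pairs are thus compatible with one common size for this change on both cores, but they do not show that the shorter chain enlarges it, and two pairs cannot show that it would carry to any further core. The other steps to this compound are a 2.4-fold higher number from compound 2 to compound 4 (0.39 log units; beyond the scatter) and a 3.4-fold higher number from compound 1 to compound 4 (0.53 log units; beyond the scatter), so with all of its steps beyond the scatter, compound 4 is the weakest inhibitor of growth of the four.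

The compounds shown leave open what a carboxylic acid or an amine would give in place of the methoxycarbonyl or hydroxymethyl, and whether the change behaves alike on a longer chain. They also leave open how much of the growth inhibition depends on the silyl group, which all four compounds carry.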